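The source may hold more compounds than are shown below. What is called first, only, known or untested is meant among the compounds shown, and "the series" means these compounds.

Measured in a functional assay on MDA-MB-231 cells (Homo sapiens) for inhibition, read by MTT assay, with a stated time of 72 h; a higher number here means a weaker inhibitor, a lower number a stronger inhibitor:
compound 1 `CC(C)COC(=O)NCCOc1ccc(Cl)cc1C(=O)N[C@H](C(=O)Nc1ccc([N+](=O)[O-])cc1Cl)C(C)C`: 4900 nM
compound 2 `CC(C)[C@H](NC(=O)c1cc(Cl)ccc1OCCCNC(=O)OC(C)(C)C)C(=O)Nc1ccc([N+](=O)[O-])cc1Cl`: > 10000 nM (a limit, not a number)
compound 3 `CC(C)[C@H](NC(=O)c1cc(Cl)ccc1OCCCN)C(=O)Nc1ccc([N+](=O)[O-])cc1Cl`: 6770 nM

Compound 3 gives 6770 nM, which lies within the scatter of compound 1 at 4900 nM. Going by the values given here, these are the only two actual numbers in the set. Compound 2 is known only as a limit.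

The next compound is compound 4 `CC(C)[C@H](NC(=O)c1cc(Cl)ccc1OCCCCN)C(=O)Nc1ccc([N+](=O)[O-])cc1Cl`. The change is aminomethyl in place of amino on a saturated chain carbon, three bonds along the chain from an oxygen on an aromatic ring. The same difference reads 3-aminopropyl to 4-aminobutyl.

Among the compounds with values here, no measured step isolates this change. The nearest is the step of a 1.4-fold higher number from compound 1 to compound 3 (0.14 log units; within the scatter), which puts aminomethyl in place of (isobutoxycarbonyl)amino. The removal of tert-butoxycarbonyl gives the step of an at least 1.4-fold lower number from compound 2 to compound 3 (0.16 log units; that floor lies within the scatter), which is only a floor. Neither supports a step beyond the scatter, so none is expected in this assay here. The expected step is a 1.2-fold lower number from compound 3 to compound 4 (0.09 log units; within the scatter). For compound 4 the estimated value is 5500 nM, with an expected range from 2500 nM to 10000 nM.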

Compound 4, half-maximal inhibitory concentration: 5590 nM
For compound 4 the middle estimate is 1.0-fold (0.01 log units) below the measured one, within the range that was stated.
By their numbers in this assay, from the lowest: compounds 1, 4 and 3 (each within the scatter of the next). At a limit, above all of these: compound 2.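

In this assay, going by these compounds alone, going from 3-aminopropyl to 4-aminobutyl gives a 1.2-fold lower number from compound 3 to compound 4 (0.08 log units; within the scatter), the first reading of chain length at this position with the free amine held at the chain end. Placing 2-aminoethyl in place of (isobutoxycarbonyl)amino gives a 1.1-fold higher number from compound 1 to compound 4 (0.06 log units; within the scatter), so a free amine on the longer chain and the capped amine of compound 1 are not separated by these values. Placing aminomethyl in place of (tert-butoxycarbonyl)amino gives an at least 1.7-fold lower number from compound 2 to compound 4 (0.25 log units; that floor lies within the scatter), which is only a floor, and compound 2 stands at a limit: the limit of > 10000 nM in this assay, at which 1 of the 4 values shown sits.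

On these data alone, whether a longer chain such as 5-aminopentyl, a dimethylamino group or a carboxylic acid at the chain end would give a step beyond the scatter remains open. All four compounds share the same core, so these readings apply to that core alone.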